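Ring stereocentre change from compound 2 to compound 4

The compounds below may be only part of what the source reports. "The series", "measured", "known", "first", "only" and "open" are said of these compounds alone.

Measured so far:
compound 1 `C=C/C=C\[C@H](C)[C@H](OC(N)=O)[C@@H](C)[C@H](O)CC/C=C\C(C)[C@@H](O)[C@@H](C)/C=C\CC[C@@H]1OC(=O)[C@H](C)[C@@H](OCOC)[C@@H]1C` gives 0.65 nM
compound 2 `COCOC1=C(C)C(=O)O[C@@H](CC/C=C\[C@H](C)[C@H](O)C(C)/C=C\CC[C@@H](O)[C@H](C)[C@@H](OC(N)=O)C(C)C)[C@@H]1C` gives > 50 nM as a limit
compound 3 `CC1=C(O)O[C@@H](CC/C=C\[C@H](C)[C@H](O)C(C)/C=C\CC[C@@H](O)[C@H](C)[C@@H](OC(N)=O)C(C)C)[C@H](C)C1=O` gives > 50 nM as a limit

All three entries come from a functional assay on 2008 cells (Homo sapiens) for inhibition (on this read-out higher numbers stand for weaker inhibition of growth and lower numbers for stronger inhibition of growth), and only compound 1 carries a true number. Compound 2 stands at the limit of > 50 nM in this assay, at which 2 of the 3 values shown sit, and gives no number, so its place in the series is known only as a limit. Compound 3 shares that same limit, so no order can be drawn between compound 2 and compound 3.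

Compound 4 `COCOC1=C(C)C(=O)O[C@@H](CC/C=C\[C@H](C)[C@H](O)C(C)/C=C\CC[C@@H](O)[C@H](C)[C@@H](OC(N)=O)C(C)C)[C@H]1C` has not yet been measured. Against compound 2 the difference is the two compounds have the same atoms and bonds; at least one stereo element is drawn with a configuration in one of them and without one in the other: 1 of 10 stereo elements differ; a stereocentre at a saturated ring carbon is drawn S in compound 2 and R in compound 4 and nothing else, the same atoms and bonds, with a stereocentre at a saturated ring carbon drawn S in compound 2 and R in compound 4. Going by the values given here, no measured step shows what such a change does. The expectation therefore rests on compound 2 alone, whose > 50 nM is a limit. The expected outcome in this assay is no step beyond the scatter, with no direction favoured, and the estimated move is a step that the limit leaves unreadable from compound 2 to compound 4 as a nominal figure only. Compound 4 is estimated at 80 nM with an expected range from 30 nM to 500 nM. A limit may well be expected again for this compound.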

Compound 4, concentration for 50% growth inhibition: > 50 nM
Compound 4 ended at the assay's limit; the forecaster's own chance of this, stated with the estimate: 75%; the middle value is on the limit's open side.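

No step from compound 2 to compound 4 can be read in this assay, because both compounds rest on the same value, which is a limit and not a number: the limit of > 50 nM in this assay, at which 3 of the 4 values shown sit.

The compounds shown leave open what the saturated ring carbon stereocentre, drawn S in compound 2 and R in compound 4, does to growth inhibition.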